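From Carbonyl to Methylene on a Ring Nitrogen

The source may hold more compounds than are shown below. What is called first, only, known or untested is meant among the compounds shown, and "the series" means these compounds.

Compound 1 `CS(=O)(=O)c1cnc(O[C@H]2CC[C@H](OC3CCN(C(=O)Oc4ccccc4)CC3)CC2)cn1` and compound 2 `CS(=O)(=O)c1cnc(O[C@H]2CC[C@H](OC3CCN(C(=O)C4(C(F)(F)F)CCCC4)CC3)CC2)cn1` share one core. In a functional assay on isolated protein for agonist activity at Glucose-dependent insulinotropic receptor (Homo sapiens), read by HTRF and cAMP accumulation (on this read-out lower numbers stand for smaller maximal responses and higher numbers for larger maximal responses), compound 1 gives 116%, while compound 2 gives 95%, the lower of the two values; that change was a number 21 percentage points lower from compound 1 to compound 2 (beyond the scatter). Compound 3 `CS(=O)(=O)c1cnc(O[C@H]2CC[C@H](OC3CCN(CC4(C(F)(F)F)CCC4)CC3)CC2)cn1` differs from compound 2 by a group of 9 heavy atoms (6 carbon, 3 fluorine; one four-membered non-aromatic ring of carbon only) in place of a group of 11 heavy atoms (7 carbon, 1 oxygen, 3 fluorine; one five-membered non-aromatic ring of carbon only), on an amine nitrogen in a ring. For the measured compounds named here, the single measured step only swapped the group on the carbonyl carbon, and no step removes that carbonyl itself, so it offers just a rough guide. A modest shift, expected as a number 5 percentage points lower from compound 2 to compound 3 (within the scatter), seems plausible in either direction. Compound 3 is therefore expected to give 90% in this assay, within 65% to 115%.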

Compound 3, largest response reached (Emax), in percent of the reference or control that the assay uses: 96%
Compound 3: middle estimate off by 6 percentage points, on the low side; measured number inside the range.
By their numbers in this assay, from the lowest: compounds 2 and 3 (each within the scatter of the next); then compound 1.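

With (1-(trifluoromethyl)cyclobutyl)methyl on the amine nitrogen in a ring, the carbonyl is gone, and the result is a number 1 percentage points higher from compound 2 to compound 3 (within the scatter), so a large response in this assay does not need that carbonyl. Set against the phenoxycarbonyl group, the same replacement gives a number 20 percentage points lower from compound 1 to compound 3 (beyond the scatter). Nothing shown here explains either result.

Ring size and carbonyl change together in the step to compound 3, so their separate contributions remain unknown. As far as these compounds go, how a benzyl group on this nitrogen would behave also remains open.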